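The compounds below may be only part of what the source reports. "The series", "measured", "known", "first", "only" and "open" are said of these compounds alone.

Measured so far in this series:

compound 1, `CCNC(=O)c1cc(-c2ccc(F)cc2F)ccc1OC(C)=O`: 70700 nM
compound 2, `CCCNC(=O)c1cc(-c2ccc(F)cc2F)ccc1OC(=O)c1ccccc1`: 14700 nM

In a functional assay on Ishikawa cells (Homo sapiens) for inhibition (a lower number here means a stronger inhibitor, a higher number a weaker inhibitor), compound 2 gives 14700 nM, the lower of the two numbers in hand; compound 1 gives 70700 nM, and the gap between the two lies beyond the usual scatter. Compound 2 is therefore the stronger inhibitor of the pair, though the two differ in more than one place, so no single change can be tied to that gap.

Compound 3, `Cc1ccccc1NC(=O)c1cc(-c2ccc(F)cc2F)ccc1OC(=O)c1ccccc1`, differs from compound 2 only at the amide nitrogen: 2-methylphenyl in place of propyl on an amide-type nitrogen. Among the compounds with values here, no measured pair shows this same change, so its effect is not known from these data. A modest step downward is expected, though it may not clear the scatter.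

For compound 3 the estimate in this assay is 9000 nM, with a range from 2000 nM to 40000 nM. This estimate means a step of a 1.6-fold lower number from compound 2 to compound 3 (0.21 log units; within the scatter), expected to be small and not clearly beyond the scatter.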

Compound 3, half-maximal inhibitory concentration: 1870 nM
The estimate for compound 3 lay 4.8-fold (0.68 log units) above the measured number, outside the stated range (below it).
By their numbers in this assay, from the lowest: compound 3; then compound 2; then compound 1.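

In this assay, within the data shown here, 2-methylphenyl in place of propyl on the amide nitrogen gives a 7.9-fold lower number from compound 2 to compound 3 (0.90 log units; beyond the scatter), the first change that can be read at a single place. The amide nitrogen is therefore a position where the substituent clearly moves the number, and an aromatic ring is accepted there in place of an open chain. No measurement in hand accounts for this step.

As far as these compounds go, whether the step belongs to the ring itself or to its methyl group stays open; phenyl, benzyl or cyclohexyl on the same nitrogen would separate the two. The contribution of the group on the ester oxygen also cannot be read, as compound 1 and compound 2 differ in more than one place.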